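Chromone acrylamide series: aryl versus benzyl amide substituent

This account rests on a few compounds, and the source may have more. Where it says the series, first, only, none or still open, it means among the compounds named here.

Compound 2 `COc1ccc2c(=O)c(/C=C/C(=O)NCc3cccc(F)c3)coc2c1` gives 10100 nM in a functional assay on Huh-7 cells (Homo sapiens) for inhibition, read by MTT assay, with a stated time of 48 h (on this read-out higher numbers stand for weaker inhibition and lower numbers for stronger inhibition), the lowest of the two numbers in hand. Its nearest neighbour is compound 1 `COc1ccc2c(=O)c(/C=C/C(=O)Nc3ccccc3Cl)coc2c1`, which in this assay gives 58400 nM. Compound 3 `O=C(/C=C/c1coc2cc(O)ccc2c1=O)NCc1ccc(F)cc1`, with a hydroxy group on the shared core, gives in this assay only a limit, > 100000 nM, which is a limit of the assay and not a number.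

Within the data shown here, the single measured step between numbered compounds is a 5.8-fold lower number from compound 1 to compound 2 (0.76 log units; beyond the scatter), and it sets the reference for the change at hand. Compound 4 `COc1ccc2c(=O)c(/C=C/C(=O)Nc3ccc(Cl)cc3)coc2c1` differs from compound 2 by 4-chlorophenyl in place of 3-fluorobenzyl on an amide-type nitrogen. This reverses the type of substituent on the amide nitrogen: compound 1 carries an aryl group there and compound 2 a benzyl group, so compound 4 returns to an aryl amide of the kind seen in compound 1, with a different halogen at a different ring position. Among the measured compounds shown here, no measured pair separates the two aryl substituents from each other, so the halogen change itself cannot be sized from the data.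

The expectation is therefore a step back towards the number of compound 1, of the order of a 3.5-fold higher number from compound 2 to compound 4 (0.54 log units; beyond the scatter) but with wide uncertainty because the step of a 5.8-fold lower number from compound 1 to compound 2 (0.76 log units; beyond the scatter) mixes the aryl-to-benzyl change with a change of halogen and position. Compound 4 is estimated at 35000 nM in this assay, in a range from 12000 nM to 100000 nM.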

Compound 4, half-maximal inhibitory concentration: 37100 nM
For compound 4 the middle estimate is 1.1-fold (0.03 log units) below the measured one; the measured number falls inside the stated range.
By their numbers in this assay, from the lowest: compound 2; then compounds 4 and 1 (each within the scatter of the next). At a limit, above all of these: compound 3.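

In this assay the change to 4-chlorophenyl on the amide-type nitrogen gives a 3.7-fold higher number from compound 2 to compound 4 (0.57 log units; beyond the scatter) and so places a second chlorophenyl amide apart from the 3-fluorobenzyl amide. The other step, a 1.6-fold lower number from compound 1 to compound 4 (0.20 log units; within the scatter), lies within the scatter, so 2-chlorophenyl and 4-chlorophenyl on this nitrogen cannot be told apart in this pair. The earlier step between compound 1 and compound 2 therefore no longer rests on a single aryl amide: both chlorophenyl amides stand apart from 3-fluorobenzyl, although compound 2 remains the only benzyl amide with a number in this comparison.

The compounds shown leave open whether the difference follows the benzyl group itself or the change of halogen, a question that a 4-chlorobenzyl group on the same nitrogen of the shared core would address, while a longer chain such as 2-phenylethyl remains an open extension at this position. The values in hand give no cause for either step.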